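Swapping thiophene for pyridine on the shared core

The source may hold more compounds than are shown below. What is called first, only, known or untested is meant among the compounds shown, and "the series" means these compounds.

Values in a functional assay on HL-60 cells (Homo sapiens) for cytotoxicity, read by ELISA, with a stated time of 2 days; a higher number here means a weaker inhibitor, a lower number a stronger inhibitor:
- Compound 1 `Oc1ccc(-c2cc(-c3ccccc3)cc(-c3ccccc3)n2)cc1`: 1400 nM
- Compound 2 `Oc1ccc(-c2cc(-c3ccccc3)cc(-c3ccsc3)n2)cc1`: 3600 nM

Compound 2 has the higher of the two numbers in this assay, making it the weaker inhibitor of the pair. Compound 3 `Oc1ccc(-c2cc(-c3ccccc3)cc(-c3cccnc3)n2)cc1` changes one ring of compound 2: pyridin-3-yl in place of thiophen-3-yl on an aromatic carbon. The new ring, pyridin-3-yl, is six-membered, as the phenyl of compound 1 is. Among the compounds with values here, the only measured step at this place is a 2.6-fold higher number from compound 1 to compound 2 (0.41 log units; beyond the scatter), which is modest. One step is thin evidence, but a partial return toward compound 1 seems likely. The expected change is a 1.6-fold lower number from compound 2 to compound 3 (0.21 log units; within the scatter). For compound 3 the estimated value is 2200 nM, with an expected range of 800 nM to 6000 nM.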

Compound 3, half-maximal inhibitory concentration: 4100 nM
Estimate against measurement, compound 3: 1.9-fold (0.27 log units) below; the measured number falls inside the stated range.
By their numbers in this assay, from the lowest: compound 1; then compounds 2 and 3 (each within the scatter of the next).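

In this assay, swapping one ring for the other at this position gives a 1.1-fold higher number from compound 2 to compound 3 (0.06 log units; within the scatter) so thiophen-3-yl and pyridin-3-yl cannot be told apart here. Ring size alone does not restore the number of compound 1: a six-membered ring is back, yet the change from phenyl gives a 2.9-fold higher number from compound 1 to compound 3 (0.47 log units; beyond the scatter) and both rings with a hetero atom stand apart from phenyl. Nothing measured here explains this result. Still open, going by these compounds, is how a furan ring, or a phenyl ring carrying an amine or a carboxylic acid, would behave at this position.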